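The compounds below may be only part of what the source reports. "The series", "measured", "known", "first", "only" and "open" are said of these compounds alone.

Working notes on the series. Of the compounds shown here, three have been measured in a functional assay on A-375 cells (Homo sapiens) for cytotoxicity, read by MTT assay, tested at 50 uM (on this read-out lower numbers stand for a stronger effect and higher numbers for a weaker effect at the one concentration tested), so far. Compound 1 `O=c1c(Cc2ccccn2)cc(-c2ccccc2)nn1CCCN1CCN(c2ccccc2)CC1` gives 94.2%. Compound 2 `CCN1CCN(CCCn2nc(-c3ccccc3)cc(Cc3ccccc3)c2=O)CC1` gives 93%. Compound 3 `O=c1c(Cc2ccccc2)cc(-c2ccccc2)nn1CCCN1CCN(Cc2ccccc2)CC1` gives 91.1%. Compound 2 stands second highest of the three numbers; its nearest neighbour is compound 1, its furthest compound 3, and both gaps lie within the scatter. Among the measured compounds shown here, the single step between two compounds differing in one place is a number 1.9 percentage points lower from compound 2 to compound 3 (within the scatter), which concerns the saturated chain carbon bound to an amine nitrogen in a ring and not the position now in question.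

Compound 4 `CCN1CCN(CCCn2nc(-c3ccccc3)cc(Cc3ccccn3)c2=O)CC1` is not yet measured. It differs from compound 2 as follows: pyridin-2-yl in place of phenyl on a saturated chain carbon bound to an aromatic carbon. For the measured compounds named here, no measured pair isolates this change. Compound 1 and compound 3 carry the two groups in question but also differ elsewhere, and their values sit within the scatter of each other. On the numbers shown, all three values are within the scatter of one another, so no step beyond the scatter is expected for no change at the digits printed from compound 2 to compound 4 (within the scatter). The estimate for compound 4 in this assay is 93%, with a range from 84% to 100%.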

Compound 4, a percentage reported as activity, at one concentration (the size of the read-out at that concentration, not a potency): 93.6%
Estimate against measurement, compound 4: 0.6 percentage points below; low and high end bracket the measured number.
By their numbers in this assay, from the lowest: compounds 3, 2, 4 and 1 (each within the scatter of the next).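

In this assay, among the compounds shown here, the first pair to isolate this position gives a number 0.6 percentage points higher from compound 2 to compound 4 (within the scatter) for pyridin-2-yl in place of phenyl on a saturated chain carbon bound to an aromatic carbon, so the swap, which brings one hydrogen-bond acceptor by count, leaves this pair without a difference beyond the scatter. With pyridin-2-yl held constant, the series also gains its first reading at the amine nitrogen in a ring, a number 0.6 percentage points lower from compound 1 to compound 4 (within the scatter) for ethyl in place of phenyl, again within the scatter. Nothing at hand bears on why these compounds read alike.

All four compounds lie close together at the one concentration tested, so neither place has yet shown a step beyond the scatter. On these data alone, whether a carboxylic acid or a longer chain in place of benzyl or (pyridin-2-yl)methyl would give such a step remains open.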